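Thiophene-sulfonylurea series: methylsulfanyl replacing chloro at the ring

A few compounds are considered here, and "the series" means these few. Any claim that something is new, unique, unknown or untested is made for them only; others in the source may bear on it.

Compound 2 `O=C(Nc1ccc(Cl)cc1)NS(=O)(=O)c1ccc(Cl)s1` gives 89% in a functional assay on the whole organism (6C3HED cells, Mus musculus) for inhibition, at a dose of 300 mg/kg by the oral route (on this read-out higher numbers stand for more inhibition at the one dose given (going by the name of the read-out) and lower numbers for less inhibition), and stands highest of the three measured compounds, ahead of compound 1 `O=C(Nc1ccc(Cl)cc1)NS(=O)(=O)c1cccs1` with 66% and of compound 3 `Cc1ccc(S(=O)(=O)NC(=O)Nc2ccc(Cl)c(Cl)c2)s1` with 61%. Going by the values given here, the one single-place step measured, a number 23 percentage points higher from compound 1 to compound 2 (beyond the scatter), shows that the position now being varied responds to substitution. Compound 4 `CSc1ccc(S(=O)(=O)NC(=O)Nc2ccc(Cl)cc2)s1` differs from compound 2 by methylsulfanyl in place of chloro on an aromatic carbon. Among the compounds with values here, no measured step exchanges one substituent for another at this site, so the bearing of a number 23 percentage points higher from compound 1 to compound 2 (beyond the scatter) is indirect: it only says that a group there is preferred over none. Compound 4 is therefore expected to stay near compound 2, with a slight drop possible, estimated at 78% with a range of 58% to 93%, a step of a number 11 percentage points lower from compound 2 to compound 4 (beyond the scatter) that is expected to fall within the scatter.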

Compound 4, a percentage reported as inhibition, in the whole organism at one dose (the size of the read-out at that dose, not a potency): 62%
Compound 4: the middle estimate sits 16 percentage points above what was measured, and the stated range covers the measured number.
By their numbers in this assay, from the lowest: compounds 3, 4 and 1 (each within the scatter of the next); then compound 2.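

In this assay, the gain at this position depends on the group: methylsulfanyl in place of chloro gives a number 27 percentage points lower from compound 2 to compound 4 (beyond the scatter) and largely cancels the gain seen with chloro, while methylsulfanyl in place of hydrogen gives a number 4 percentage points lower from compound 1 to compound 4 (within the scatter) here. A group on this aromatic carbon is thus not enough in itself, since chloro gives a gain over hydrogen and methylsulfanyl gives none. Nothing available explains the loss.

From the compounds shown here alone, whether bromo or an amine at this site would match chloro remains open. So does whether a longer chain, such as ethylsulfanyl, would behave like methylsulfanyl.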